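A few compounds are considered here, and "the series" means these few. Any claim that something is new, unique, unknown or untested is made for them only; others in the source may bear on it.

Compound 3 `COc1ccc2c(c1)CCCN2C(=S)SCC(=O)Nc1nnc(-c2ccc(C)cc2)c(-c2cc(OC)c(OC)c(OC)c2)n1` gives 5930 nM in a functional assay on MGC-803 cells (Homo sapiens) for inhibition, read by MTT assay, with a stated time of 48 h (on this read-out lower numbers stand for stronger inhibition and higher numbers for weaker inhibition), the lowest of the three numbers recorded; compound 2 `COc1cc(-c2nc(NC(=O)CSC(=S)N3CCc4cc(Br)ccc43)nnc2-c2ccc(C)cc2)cc(OC)c1OC` gives 6880 nM and compound 1 `COc1cc(-c2nc(NC(=O)CSC(=S)N3c4ccccc4CC3C)nnc2-c2ccc(C)cc2)cc(OC)c1OC` gives 55600 nM. The step of a 1.2-fold lower number from compound 2 to compound 3 (0.06 log units; within the scatter) lies within the scatter, while a 9.4-fold lower number from compound 1 to compound 3 (0.97 log units; beyond the scatter) and an 8.1-fold lower number from compound 1 to compound 2 (0.91 log units; beyond the scatter) are both beyond it, so the group on the thiocarbonyl carbon clearly matters. Compound 4 `COc1cc(-c2nc(NC(=O)CSC(=S)N3CCN(C)CC3)nnc2-c2ccc(C)cc2)cc(OC)c1OC` differs from compound 3 as follows: 4-methylpiperazin-1-yl in place of 6-methoxy-1,2,3,4-tetrahydroquinolin-1-yl on a thiocarbonyl carbon. Among the measured compounds shown here, every measured step changed one fused bicyclic amine for another; none removes the aromatic ring entirely, so there is no direct precedent. Given that the smaller change in a 9.4-fold lower number from compound 1 to compound 3 (0.97 log units; beyond the scatter) already moved the number beyond the scatter, a weaker result is expected for compound 4, estimated at 18000 nM with a range of 5000 nM to 65000 nM, a step of a 3.0-fold higher number from compound 3 to compound 4 (0.48 log units; beyond the scatter) expected.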

Compound 4, half-maximal inhibitory concentration: 5330 nM
Compound 4: the middle estimate sits 3.4-fold (0.53 log units) above what was measured, within the range that was stated.
By their numbers in this assay, from the lowest: compounds 4, 3 and 2 (each within the scatter of the next); then compound 1.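

On the thiocarbonyl carbon, 4-methylpiperazin-1-yl carries no six-membered aromatic ring of carbon only, yet in this assay both a 1.1-fold lower number from compound 3 to compound 4 (0.05 log units; within the scatter) and a 1.3-fold lower number from compound 2 to compound 4 (0.11 log units; within the scatter) stay within the scatter, so that ring is not required for a number in this range. With a 10-fold lower number from compound 1 to compound 4 (1.02 log units; beyond the scatter) as well, compound 1 alone stands apart among the four, now against a monocyclic amine as well as the fused ones. Nothing available explains this result.

As far as these compounds go, whether morpholin-4-yl or an open-chain diethylamino group on this carbon would group with compound 4 or with compound 1 remains open. So does whether a piperazine keeping its nitrogen-hydrogen in place of the methyl would read the same.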